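This account rests on a few compounds, and the source may have more. Where it says the series, first, only, none or still open, it means among the compounds named here.

The measured compounds and their numbers:

compound 1 `Cn1c(Sc2c(F)cc(C(=O)NO)cc2F)nnc1-c1cccs1` — 9 nM
compound 2 `Cn1c(Sc2c(F)cc(C(=O)NO)cc2F)nnc1-c1cccnn1` — 13 nM
compound 3 `O=C(NO)c1ccc(Cn2nnc(-c3ncccn3)n2)cc1` — 7 nM

In an assay on Sf9 cells for inhibition of protein deacetylase HDAC6 (Homo sapiens), read by fluorescence (a higher number here means a weaker inhibitor, a lower number a stronger inhibitor), compound 2 gives 13 nM, the highest of the three numbers. Its nearest neighbour is compound 1, and the furthest is compound 3, yet both gaps lie within the usual scatter, so the three compounds cannot be ranked against one another on these data.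

The change from compound 2 to compound 4 `Cc1cc(-c2nnc(Sc3c(F)cc(C(=O)NO)cc3F)n2C)nn1C` is 1,5-dimethyl-1H-pyrazol-3-yl in place of pyridazin-3-yl on an aromatic carbon. For the measured compounds named here, only one measured step bears on it: the exchange of one aromatic ring for another at the same position on the shared core, which gave a 1.4-fold higher number from compound 1 to compound 2 (0.16 log units; within the scatter). Going by the values given here, that step stayed within the scatter, and no other measured pair speaks to the new ring.

Compound 4 is therefore expected to show a number close to that of compound 2, with a step of about a 1.1-fold higher number from compound 2 to compound 4 (0.03 log units; within the scatter) and no change beyond the scatter. The estimate for compound 4 in this assay is 14 nM, expected to fall between 6 nM and 35 nM.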

Compound 4, half-maximal inhibitory concentration: 6 nM
The estimate for compound 4 lay 2.3-fold (0.37 log units) above the measured number; the range from low to high includes it.
By their numbers in this assay, from the lowest: compounds 4, 3, 1 and 2 (each within the scatter of the next, the first and the last beyond it).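

In this assay, for the compounds shown here, the ring on this aromatic carbon of the shared core now makes a difference beyond the scatter for the first time: 1,5-dimethyl-1H-pyrazol-3-yl in place of pyridazin-3-yl gives a 2.2-fold lower number from compound 2 to compound 4 (0.34 log units; beyond the scatter), a modest step. The same ring in place of thiophen-2-yl gives a 1.5-fold lower number from compound 1 to compound 4 (0.18 log units; within the scatter), so the position separates 1,5-dimethyl-1H-pyrazol-3-yl from pyridazin-3-yl but not from thiophen-2-yl. No measurement shown here accounts for the step.

The change swaps a six-membered ring for a five-membered one and adds two methyl groups at once, and a pyrazole ring without those methyl groups would be needed to tell the two apart. On these data alone, how the position responds to a ring carrying an amine or a carboxylic acid also remains open.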